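Swapping a tert-butyl for a dimethylaminomethyl group

This account rests on a few compounds, and the source may have more. Where it says the series, first, only, none or still open, it means among the compounds named here.

Of the compounds shown here, two sharing one core have been measured in a functional assay for agonist activity at G protein-coupled receptor 88 (Homo sapiens), read by HTRF and cAMP accumulation; on this read-out lower numbers stand for an effect already at smaller amounts and higher numbers for an effect only at larger amounts of compound. Compound 1 `CC[C@H](C)[C@H](N)CN(C(=O)[C@@H]1C[C@H]1c1ccsc1)c1ccc(-c2ccccc2)cc1` gives 450 nM in this assay. Compound 2 `CC[C@H](C)[C@H](N)CN(C(=O)[C@@H]1C[C@H]1c1ccccc1)c1ccc(-c2ccc(C(C)(C)C)cc2)cc1` gives 750 nM in this assay; the numbers of compound 2 and compound 1 lie within the usual scatter of each other, so the two cannot be told apart on this evidence. Compound 3 `CC[C@H](C)[C@H](N)CN(C(=O)[C@@H]1C[C@H]1c1ccccc1)c1ccc(-c2ccc(CN(C)C)cc2)cc1` has not yet been measured. It differs from compound 2 in one place: (dimethylamino)methyl in place of tert-butyl on an aromatic carbon. Among the measured compounds shown here, no measured pair shows this same change, so there is no earlier step to lean on. The expectation is therefore that the step from compound 2 to compound 3 is small, a 1.2-fold higher number from compound 2 to compound 3 (0.08 log units; within the scatter), without a clear direction beyond the scatter. Compound 3 is thus estimated at 900 nM in this assay, with a range from 300 nM to 3000 nM.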

Compound 3, half-maximal effective concentration: 460 nM
Compound 3: the middle estimate sits 2.0-fold (0.29 log units) above what was measured; the measured number falls inside the stated range.
By their numbers in this assay, from the lowest: compounds 1, 3 and 2 (each within the scatter of the next).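

In this assay this position now has its first direct comparison, which gives a 1.6-fold lower number from compound 2 to compound 3 (0.21 log units; within the scatter), so 4-(tert-butyl)phenyl and 4-((dimethylamino)methyl)phenyl cannot be told apart on this read-out. On the six-membered aromatic ring of carbon only, para to a large group, a group with a nitrogen and one hydrogen-bond acceptor can thus stand in place of an all-carbon group of the same heavy-atom count without a step beyond the scatter. Nothing available explains why the two groups read alike.

The compounds shown leave open whether a carboxylic acid, a primary amine or a longer chain ending in an amine at this place would give a step beyond the scatter. Among the compounds shown here, with only one swap to read here, no trend across groups can yet be drawn.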